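Amide variation and an unmeasured isopropyl ketone analogue

The source may hold more compounds than are shown below. What is called first, only, known or untested is meant among the compounds shown, and "the series" means these compounds.

In an ADME assay on Caco-2 cells (Homo sapiens) for permeability, in the apical to basolateral direction (a lower number here means that the compound crosses the layer more slowly, a higher number that the compound crosses the layer faster), three compounds have been measured: compound 1 `Cn1cncc1CN1CC(N(CC2CCN(C(=O)CC(F)(F)F)CC2)S(=O)(=O)c2ccccn2)Cc2cc(C#N)ccc21` gives 0.5 10^-6 cm/s; compound 2 `CC(C)NC(=O)N1CCC(CN(C2Cc3cc(C#N)ccc3N(Cc3cncn3C)C2)S(=O)(=O)c2ccccn2)CC1` gives 0.6 10^-6 cm/s; compound 3 `Cn1cncc1CN1CC(N(CC2CCN(C(=O)N3CCCC3)CC2)S(=O)(=O)c2ccccn2)Cc2cc(C#N)ccc21` gives 0.6 10^-6 cm/s.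

Compound 3 stands level with compound 2, the pair sharing the highest number of the three, and its step from compound 1 is a 1.2-fold higher number from compound 1 to compound 3 (0.08 log units; within the scatter). Compound 4 `CC(C)C(=O)N1CCC(CN(C2Cc3cc(C#N)ccc3N(Cc3cncn3C)C2)S(=O)(=O)c2ccccn2)CC1` differs from compound 3 as follows: isopropyl in place of pyrrolidin-1-yl on a carbonyl carbon. Among the compounds with values here, the steps that bear on this position are a 1.2-fold higher number from compound 1 to compound 2 (0.08 log units; within the scatter), a 1.2-fold higher number from compound 1 to compound 3 (0.08 log units; within the scatter) and no change at the digits printed from compound 2 to compound 3 (within the scatter); none leaves the scatter. Within the data shown here, no measured step introduces an isopropyl here. Compound 4 is therefore expected to show no change at the digits printed from compound 3 to compound 4 (within the scatter), with an estimated value of 0.6 10^-6 cm/s, ranging from 0.3 10^-6 cm/s to 1.2 10^-6 cm/s.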

Compound 4, apparent permeability: 0.5 10^-6 cm/s
The estimate for compound 4 lay 1.2-fold (0.08 log units) above the measured number; measured number inside the range.
By their numbers in this assay, from the lowest: compounds 1, 4, 2 and 3 (each within the scatter of the next).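

In this assay the isopropyl group on the carbonyl carbon leaves the number within the scatter in all three new comparisons (a 1.2-fold lower number from compound 3 to compound 4 (0.08 log units; within the scatter); a 1.2-fold lower number from compound 2 to compound 4 (0.08 log units; within the scatter); no change at the digits printed from compound 1 to compound 4 (within the scatter)). The four compounds therefore read alike at this position, whether the group on the carbonyl carbon holds nitrogen, fluorine or only carbon and hydrogen. No evidence is available to explain these results. The compounds shown leave open whether a carboxylic acid or a primary amine at this position would produce a step beyond the scatter.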